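The compounds below may be only part of what the source reports. "The series", "measured", "known", "first", "only" and "open" are said of these compounds alone.

In a functional assay on HCT-116 cells (Homo sapiens) for inhibition, read by MTT assay, with a stated time of 48 h (a higher number here means a weaker inhibitor, a lower number a stronger inhibitor), compound 1 `COc1cc(-c2nccn3cc(-c4ccc(F)cc4)nc23)cc(OC)c1OC` gives 263 nM. Compound 2 `COc1cc(-c2nccn3cc(-c4ccc(Cl)cc4)nc23)cc(OC)c1OC` gives 351 nM, and compound 3 `COc1cc(-c2nccn3cc(-c4ccccc4)nc23)cc(OC)c1OC` gives 266 nM. Compound 1 therefore lies within the scatter of both, and the numbers set no order among the three.

Compound 4 `COc1cc(-c2nccn3cc(-c4ccc([N+](=O)[O-])cc4)nc23)cc(OC)c1OC` is the unmeasured analogue, with nitro in place of fluoro on an aromatic carbon, para to a large group: nitro in place of fluoro on an aromatic carbon. Going by the values given here, the steps that bear on it are the other changes at this same place: a 1.3-fold higher number from compound 1 to compound 2 (0.13 log units; within the scatter) and a 1.0-fold higher number from compound 1 to compound 3 (0.00 log units; within the scatter). The remaining step, a 1.3-fold lower number from compound 2 to compound 3 (0.12 log units; within the scatter), is also small, and all three lie within the scatter. Among the compounds with values here, no measured compound carries nitro, so these steps guide the expectation only loosely and the range is kept wide. In this assay no step beyond the scatter is expected, and no direction is favoured. The estimated step is a 1.1-fold higher number from compound 1 to compound 4 (0.06 log units; within the scatter). For compound 4 the expected value is 300 nM, with an estimated range of 120 nM to 750 nM.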

Compound 4, half-maximal inhibitory concentration: > 10000 nM
Compound 4 was reported as a limit (the forecaster's own chance of this, stated with the estimate: 3%); middle value at least 33-fold (1.52 log units) away from the limit.
By their numbers in this assay, from the lowest: compounds 1, 3 and 2 (each within the scatter of the next). At a limit, above all of these: compound 4.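

In this assay, going by these compounds alone, fluoro, chloro and hydrogen on this aromatic carbon, para to a large group, gave only steps within the scatter, so the earlier compounds showed no sensitivity to the group at this place; nitro is the first change here to give a large step. Nitro gives an at least 38-fold higher number from compound 1 to compound 4 (1.58 log units; beyond the scatter), and likewise an at least 37-fold higher number from compound 3 to compound 4 (1.57 log units; beyond the scatter), and an at least 28-fold higher number from compound 2 to compound 4 (1.45 log units; beyond the scatter). Compound 4 is reported as a limit and not as a number, so these steps are bounds: the limit of > 10000 nM in this assay, at which 1 of the 4 values shown sits.

From the compounds shown here alone, whether the large step belongs to nitro alone or also appears with other groups at this place, such as an amine, a nitrile or a carboxylic acid, remains open. The compounds shown also do not tell how far past its limit compound 4 lies, nor what lies behind the step.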